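Swapping the Charged Ring at the End of a Long Chain

The source may report more compounds than this note shows. Statements on the series, on what has been measured and on what is new or still open speak of the compounds shown alone.

In an assay on LX2 cells for inhibition of COL1A1 promoter (Homo sapiens), read by a luciferase reporter, with a stated time of 24 h, tested at 20 uM (on this read-out higher numbers stand for a stronger effect at the one concentration tested and lower numbers for a weaker effect), compound 1 `Cc1cc(-n2cc(C(=O)Nc3cc(F)cc(F)c3)c(=O)c3ccc(N(C)C)nc32)ccc1OCCCCCCC[N+]12CCN(CC1)CC2` gives 10.6%. That is the lower of the two numbers at hand: compound 2 `CN(C)c1ccc2c(=O)c(C(=O)Nc3cc(F)cc(F)c3)cn(-c3ccc(OCCCCCCC[N+]45CCN(CC4)CC5)cc3Cl)c2n1` gives 40.1%, a gap beyond the usual scatter. Compound 3 `Cc1cc(-n2cc(C(=O)Nc3cc(F)cc(F)c3)c(=O)c3ccc(N(C)C)nc32)ccc1OCCCCCCC[N+]1(C)CCCC1` has not been measured yet. It differs from compound 1 in one place: a group of 6 heavy atoms (5 carbon, 1 nitrogen; one five-membered non-aromatic ring with 1 hetero atom) in place of a group of 8 heavy atoms (6 carbon, 2 nitrogen; 2 six-membered non-aromatic rings with 2 hetero atoms each), on a saturated chain carbon, seven bonds along the chain from an oxygen on an aromatic ring. Among the compounds with values here, no measured pair shows what this change does, so only a small shift is expected. The expected step of a number 4.4 percentage points higher from compound 1 to compound 3 (within the scatter) is modest, upward if at all, and may lie within the scatter. Compound 3 is therefore estimated at 15%, within a range from 2% to 35%.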

Compound 3, a percentage reported as inhibition, at one concentration (the size of the read-out at that concentration, not a potency): 26.1%
For compound 3 the middle estimate is 11.1 percentage points below the measured one, within the range that was stated.
By their numbers in this assay, from the lowest: compound 1; then compound 3; then compound 2.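

The charged ring at the end of the chain does affect the read-out. In this assay the one-place swap gives a number 15.5 percentage points higher from compound 1 to compound 3 (beyond the scatter) even though both end groups carry a net charge of +1, so net charge alone does not set the number at this position. No measurement here explains the step.

The compounds shown leave open whether the same swap would raise the number for compound 2. They also leave open how a piperidine ring or a longer chain would behave at this position.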